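A Smaller Acyl Group on a Compound at the Assay Limit

The source may report more compounds than this note shows. Statements on the series, on what has been measured and on what is new or still open speak of the compounds shown alone.

Measured so far:
compound 1, `Nc1nn(C(=O)c2cccs2)c(N)c1/N=N/c1ccc(O)cc1` — > 100000 nM
compound 2, `Nc1n[nH]c(N)c1/N=N/c1cc[n+]([O-])cc1` — > 100000 nM

In a functional assay on RPMI-8226 cells (Homo sapiens) for cytotoxicity, read by fluorescence, with a stated time of 72 h (a lower number here means a stronger inhibitor, a higher number a weaker inhibitor), compound 1 gives > 100000 nM, which is a limit of the assay rather than a number. Compound 2 gives > 100000 nM, likewise a limit. Among the compounds with values here, compound 1 therefore stands at the limit of > 100000 nM in this assay, at which 2 of the 2 values shown sit, so its place among the numbers is known only as a limit, and no measured pair of compounds differs in a single place from which the size of a step could be read.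

Compound 3, `CC(=O)n1nc(N)c(/N=N/c2ccc(O)cc2)c1N`, differs from compound 1 by methyl in place of thiophen-2-yl on a carbonyl carbon. With compound 1 itself only a limit, no step beyond the usual scatter is expected, and the step from compound 1 to compound 3 is estimated as a number no higher from compound 1 to compound 3 (the limit leaves the size open). Compound 3 is expected to give 100000 nM, with a range from 30000 nM to 300000 nM.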

Compound 3, half-maximal inhibitory concentration: > 100000 nM
Compound 3: no number, only a limit (the forecaster's own chance of this, stated with the estimate: 80%); the middle value lies on the limit itself.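

In this assay compound 3 gives > 100000 nM, which is a limit and not a number. Within the data shown here, compound 1 also stands at a limit, so no step between compound 1 and compound 3 can be read. The compounds shown leave open whether any acyl group on the shared core would give a number in this assay.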